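This account rests on a few compounds, and the source may have more. Where it says the series, first, only, none or still open, it means among the compounds named here.

Measured so far:
Compound 1 `O=C(O)c1cc(-c2cncs2)ccc1O` in a functional assay on the whole organism for inhibition, with Rattus norvegicus as the target, read by paw edema (a higher number here means that more compound is needed for the effect, a lower number that less compound is needed), gives > 200 mg/kg; this is a limit of the assay and not a number.
Compound 2 `O=C(O)c1cc(-n2cccc2)ccc1O` in this assay gives 50 mg/kg.

Among the compounds with values here, compound 2 therefore holds the only actual number in this small set, since the other value is a limit. Within the data shown here, the single measured step is an at least 4.0-fold lower number from compound 1 to compound 2 (0.60 log units; beyond the scatter); because it rests on (the limit of > 200 mg/kg in this assay, at which 1 of the 2 values shown sits), only a lower bound for its size is known.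

Compound 3 `O=C(O)c1cc(-c2cocn2)ccc1O` differs from compound 2 by 1,3-oxazol-4-yl in place of 1H-pyrrol-1-yl on an aromatic carbon. This is again an exchange of one five-membered aromatic ring for another of the same size at the same position on the shared core, and the entering ring resembles the ring of compound 1 more closely than the ring it replaces. Among the measured compounds shown here, the only step that bears on it thus points in one direction, but in reverse: moving away from the ring of compound 2 gives reason to expect the number to climb part of the way back toward the limit seen for compound 1. The expected step is therefore a 2.0-fold higher number from compound 2 to compound 3 (0.30 log units; within the scatter) in this assay. For compound 3 the estimate is 100 mg/kg, within a range of 40 mg/kg to 250 mg/kg.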

Compound 3, dose for half-maximal effect: 110 mg/kg
The estimate for compound 3 lay 1.1-fold (0.04 log units) below the measured number, and the stated range covers the measured number.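

In this assay, the place para to the hydroxy group and meta to the carboxy group now has two five-membered aromatic rings with actual numbers, and they do not read alike: the exchange of 1H-pyrrol-1-yl for 1,3-oxazol-4-yl gives a 2.2-fold higher number from compound 2 to compound 3 (0.34 log units; beyond the scatter). Ring size alone therefore does not set the number here, although the step is modest. Against the sulfur-containing ring, the same exchange gives an at least 1.8-fold lower number from compound 1 to compound 3 (0.25 log units; that floor lies within the scatter), and only a floor can be stated for this step because compound 1 stands at a limit and not at a number: the limit of > 200 mg/kg in this assay, at which 1 of the 3 values shown sits.

On these data alone, it remains open whether a five-membered aromatic ring is needed here at all, as a plain phenyl ring, a chlorine atom or a short alkyl chain at this place could read quite differently. A 1H-pyrrol-2-yl group would also help to show whether the step from compound 2 to compound 3 follows the hetero atoms in the ring or the atom through which the ring is attached to the shared core.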